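Swapping the aryl group on a cyanoguanidine in a potassium-channel opener series

A few compounds are considered here, and "the series" means these few. Any claim that something is new, unique, unknown or untested is made for them only; others in the source may bear on it.

Measured so far:
compound 1 `CC1(C)Oc2ccc(C#N)cc2[C@@H](NC(=O)Nc2ccccn2)[C@@H]1O`: 440 nM
compound 2 `CC1(C)Oc2ccc(C#N)cc2[C@@H](/N=C(\NC#N)Nc2cccc(C(F)(F)F)c2)[C@@H]1O`: 1600 nM

In a functional assay (aorta) with Rattus norvegicus as the target (on this read-out higher numbers stand for weaker inhibition and lower numbers for stronger inhibition), compound 2 gives 1600 nM, the higher of the two numbers, while compound 1 gives 440 nM. The gap between them lies beyond the scatter, and the two compounds differ in more than one place, so the two values alone say nothing about any single change. Compound 3 `CSc1ccc(N/C(=N/[C@@H]2c3cc(C#N)ccc3OC(C)(C)[C@H]2O)NC#N)cc1` differs from compound 2 in one place: 4-(methylsulfanyl)phenyl in place of 3-(trifluoromethyl)phenyl on an amine nitrogen. Within the data shown here, no measured step tells how this swap acts. The step of a 1.1-fold lower number from compound 2 to compound 3 (0.03 log units; within the scatter) is expected to stay within the scatter, with no clear direction. Compound 3 is therefore estimated at 1500 nM in this assay, ranging from 400 nM to 6000 nM.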

Compound 3, half-maximal inhibitory concentration: 6300 nM
For compound 3 the middle estimate is 4.2-fold (0.62 log units) below the measured one; measured number above the stated range.
By their numbers in this assay, from the lowest: compound 1; then compound 2; then compound 3.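

In this assay, the group on this amine nitrogen clearly matters: 4-(methylsulfanyl)phenyl in place of 3-(trifluoromethyl)phenyl gives a 3.9-fold higher number from compound 2 to compound 3 (0.60 log units; beyond the scatter), meaning weaker inhibition. Among these compounds, this is the only change here made in a single place, so it gives the first direct reading for this position. Nothing available accounts for the size or direction of this step. The swap changes both the ring substituent and its place on the ring, so the two effects cannot be separated. Going by these compounds, how a plain phenyl or a chlorophenyl group would behave on this nitrogen remains open.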